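The source may report more compounds than this note shows. Statements on the series, on what has been measured and on what is new or still open speak of the compounds shown alone.

Notes on the series. Compound 1, `COc1ccc(C2N=C(SCc3ccc(Cl)cc3)NC(C)=C2C(=O)Nc2ccc(F)cc2)cc1OC`, is measured in a functional assay on the whole organism (artery, strain albino) with Rattus norvegicus as the target, with a stated time of 720 min, at a dose of 10 mg/kg by the oral route (on this read-out higher numbers stand for more inhibition at the one dose given (going by the name of the read-out) and lower numbers for less inhibition), where compound 1 gives 22.2%. Compound 2, `COc1ccc(C2N=C(SCc3ccc(F)cc3)NC(C)=C2C(=O)Nc2ccc(F)cc2)cc1OC`, differs from compound 1 by fluoro in place of chloro on an aromatic carbon; in this assay compound 2 gives 17%, and the step is a number 5.2 percentage points lower from compound 1 to compound 2 (within the scatter). Compound 3, `CC1=C(C(=O)Nc2ccc([N+](=O)[O-])cc2)C(c2cccc([N+](=O)[O-])c2)N=C(SCc2ccc(Cl)cc2)N1`, has a core that differs from the core of compound 1 in more than one place; the difference between the two cores is not broken down here. In this assay compound 3 gives 15.5%, a number within the scatter of both other values, so no order among compounds 1, 2 and 3 can be read. Compound 4, `CC1=C(C(=O)Nc2ccc([N+](=O)[O-])cc2)C(c2cccc([N+](=O)[O-])c2)N=C(SCc2ccc(F)cc2)N1`, is not yet measured; it carries the same change as the one between compound 1 and compound 2, (fluoro in place of chloro on an aromatic carbon), at the same place, so the change occurs two times among the compounds shown. For the measured compounds named here, the only measured instance of it, a number 5.2 percentage points lower from compound 1 to compound 2 (within the scatter), stayed within the scatter, and a single example is a thin basis. On that basis the step expected is a number 3.5 percentage points lower from compound 3 to compound 4 (within the scatter). For compound 4 the expected value in this assay is 12%, with an estimated range from 2% to 24%.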

Compound 4, a percentage reported as inhibition, in the whole organism at one dose (the size of the read-out at that dose, not a potency): 20.1%
Estimate against measurement, compound 4: 8.1 percentage points below; the measured number falls inside the stated range.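

On the core of compound 3, the step for fluoro in place of chloro is a number 4.6 percentage points higher from compound 3 to compound 4 (within the scatter) in this assay. Set beside the earlier step, the signs are opposite, but this cannot be read as a reversal between the two cores: the same change on two cores in this assay, a number 5.2 percentage points lower (within the scatter) from compound 1 to compound 2 and a number 4.6 percentage points higher (within the scatter) from compound 3 to compound 4, 9.8 percentage points apart, within the scatter of two such steps

What this shows is that on neither core does the change give a step that can be told from the scatter, so the data give no sign that it carries a usable effect from one core to another. It does not show that the two cores respond alike, nor that the change is without effect, as two small steps cannot settle either point.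

The compounds shown offer only chloro and fluoro on the benzyl group, so it stays open whether an amine or a carboxylic acid at that place would give a step beyond the scatter. As far as these compounds go, a longer chain in place of the 4-fluorobenzyl group is equally open, and so is any dose response on either core.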